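Benzyl in place of 4-phenylphenyl in a triazole acetamide series

A few compounds are considered here, and "the series" means these few. Any claim that something is new, unique, unknown or untested is made for them only; others in the source may bear on it.

Compound 1 `CCCCCCCCCCCCn1nnc(C(C(=O)Nc2c(OC)cc(OC)cc2OC)c2ccc(OC)cc2)n1`: 61%
Compound 2 `CCCCCCCCCCCCn1nnc(C(C(=O)Nc2c(OC)cc(OC)cc2OC)c2ccc(N(C)C)cc2)n1`: 0%
Compound 3 `CCCCCCCCCCCCn1nnc(C(C(=O)Nc2c(OC)cc(OC)cc2OC)c2ccc(-c3ccccc3)cc2)n1`: 10%

In an assay on isolated protein for inhibition of sterol O-acyltransferase 1 (Mus musculus), tested at 0.1 uM (a lower number here means less inhibition, a higher number more inhibition at the concentration tested (going by the name of the read-out)), compound 1 gives 61%, compound 2 gives 0% and compound 3 gives 10%. Compound 3 thus stands second highest of the three numbers: its nearest neighbour is compound 2, since a number 10 percentage points higher from compound 2 to compound 3 (within the scatter), and its furthest is compound 1, since a number 51 percentage points lower from compound 1 to compound 3 (beyond the scatter).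

Compound 4 `CCCCCCCCCCCCn1nnc(C(Cc2ccccc2)C(=O)Nc2c(OC)cc(OC)cc2OC)n1` differs from compound 3 in one place: benzyl in place of 4-phenylphenyl on a saturated chain carbon bound to an aromatic carbon and a carbonyl carbon. Among the measured compounds shown here, none of the measured steps exchanges an aromatic group for a group attached through a saturated carbon, so no step bears on this change directly. The closest guidance is that a number 51 percentage points lower from compound 1 to compound 3 (beyond the scatter), a large step, and that a number 10 percentage points higher from compound 2 to compound 3 (within the scatter), a step within the scatter. For the measured compounds named here, because 10% is low for compound 3 and the only high number came from compound 1 with a methoxy group, compound 4 is expected to land near compound 3 or somewhat higher, with a number 15 percentage points higher from compound 3 to compound 4 (beyond the scatter) as the expected step. Compound 4 is therefore estimated at 25%, within a range from 0% to 60%.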

Compound 4, a percentage reported as inhibition, at one concentration (the size of the read-out at that concentration, not a potency): 77%
Beside the measured number, compound 4's estimate is 52 percentage points below it, and the stated range ends below it.
By their numbers in this assay, from the lowest: compounds 2 and 3 (each within the scatter of the next); then compound 1; then compound 4.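

In this assay the saturated chain carbon bound to an aromatic carbon and a carbonyl carbon accepts benzyl far better than two of the substituted phenyl groups: a number 67 percentage points higher from compound 3 to compound 4 (beyond the scatter) with benzyl in place of 4-phenylphenyl, and a number 77 percentage points higher from compound 2 to compound 4 (beyond the scatter) with benzyl in place of 4-(dimethylamino)phenyl. Benzyl also surpasses the best phenyl group shown, as a number 16 percentage points higher from compound 1 to compound 4 (beyond the scatter) with benzyl in place of 4-methoxyphenyl, so a high number at this carbon is no longer confined to compound 1. No measurement shown here accounts for these steps.

The compounds shown leave open whether an unsubstituted phenyl, a 4-methoxybenzyl or a 2-phenylethyl group on this carbon would keep the number of compound 4. They also leave open whether an isobutyl group, with no aromatic ring, would do the same.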